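The source may report more compounds than this note shows. Statements on the series, on what has been measured and on what is new or still open speak of the compounds shown alone.

Measured in a physicochemical assay for lipophilicity; a lower number here means a more polar compound, a higher number a more lipophilic compound:
- compound 1 `CN1CCC(C(=O)N(CC(=O)Nc2cc(F)cc(F)c2)C2CCCCC2)CC1`: 1.8
- compound 2 `O=C(CN(C(=O)C1CCCCC1)C1CCCCC1)Nc1cc(F)cc(F)c1`: "not determined" (no result reported)

Compound 2 has no number to stand on. In this assay compound 2 gave "not determined" (no result reported), so the step that follows starts from no measured point. Compound 3 `O=C(CN(C(=O)c1cccnc1)C1CCCCC1)Nc1cc(F)cc(F)c1` comes from compound 2 by a single change, (pyridin-3-yl in place of cyclohexyl on a carbonyl carbon), that is, pyridin-3-yl in place of cyclohexyl on a carbonyl carbon. Within the data shown here, no step between measured compounds is available to size this change. Even so, a clear step towards lower readings in this assay, beyond the scatter, is expected on going to compound 3. Among the measured compounds shown here, the only number at hand is that of compound 1 at 1.8, which gives a sense of the scale but not of the step. For compound 3 the estimated value is 3, with an expected range of 2.4 to 3.6.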

Compound 3, distribution coefficient: 2.7
Beside the measured number, compound 3's estimate is 0.30 log units above it; measured number inside the range.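

Compound 3 gives this position a second measured point in this assay, and with pyridin-3-yl in place of 1-methylpiperidin-4-yl on a carbonyl carbon the comparison shows a number 0.90 log units higher from compound 1 to compound 3 (beyond the scatter) and thus that the group held there moves the reading, which compound 1 alone could not show. Compound 2 has no number in this assay and the step from it to compound 3, the cyclohexyl to pyridin-3-yl change itself, cannot be read. Nothing at hand accounts for the size of the step that can be read.

The compounds shown leave open how a carboxylic acid, a primary amine or a longer alkyl chain on this carbonyl carbon would read. They also leave open whether pyridin-3-yl in place of 1-methylpiperidin-4-yl gives a step of similar size on another core.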